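A few compounds are considered here, and "the series" means these few. Any claim that something is new, unique, unknown or untested is made for them only; others in the source may bear on it.

In an ADME assay on MT4 cells (Homo sapiens) for cytotoxicity, read by MTT assay, with a stated time of 5 days (on this read-out higher numbers stand for lower toxicity in this test and lower numbers for higher toxicity in this test), compound 2 `COc1cc2nc([S+]([O-])CC(=O)Nc3ccc(C#N)cc3)nc(Nc3c(Cl)cc(/C=C/C#N)cc3Cl)c2cc1OC` stands at >= 188000 nM, which is a limit of the assay and not a number. Compound 1 `COc1cc2nc([S+]([O-])CC(=O)Nc3cccc([N+](=O)[O-])c3)nc(Nc3c(Cl)cc(/C=C/C#N)cc3Cl)c2cc1OC` stands at >= 83200 nM, which is also a limit. The series therefore has no measured number yet in this read-out.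

Compound 3 `COc1cc2nc([S+]([O-])CC(=O)Nc3cccc(S(N)(=O)=O)c3)nc(Nc3c(Cl)cc(/C=C/C#N)cc3Cl)c2cc1OC` differs from compound 2 as follows: 3-sulfamoylphenyl in place of 4-cyanophenyl on an amide-type nitrogen. In short, 3-sulfamoylphenyl replaces 4-cyanophenyl on an amide-type nitrogen.

Among the measured compounds shown here, the only measured step at this place is a step that the two limits leave unreadable from compound 1 to compound 2, where 4-cyanophenyl replaced 3-nitrophenyl, so it offers no size to carry over. No step beyond the scatter is therefore expected in this assay, and no direction can be assigned. The expected step is an at least 1.2-fold lower number from compound 2 to compound 3 (0.09 log units; that floor lies within the scatter). Compound 3 may well report only a limit too. The estimate for compound 3 is 150000 nM, with an expected range from 40000 nM to 300000 nM.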

Compound 3, half-maximal cytotoxic concentration: 67800 nM
Beside the measured number, compound 3's estimate is 2.2-fold (0.34 log units) above it, within the range that was stated.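

In this assay, the group on the amide-type nitrogen now has a readable effect: 3-sulfamoylphenyl in place of 4-cyanophenyl gives an at least 2.7-fold lower number from compound 2 to compound 3 (0.44 log units; beyond the scatter), in the direction of higher toxicity in this test. That size is only a floor, since the value of compound 2 is a limit: the limit of >= 188000 nM in this assay, at which 1 of the 3 values shown sits. Sulfamoyl in place of nitro on an aromatic carbon gives an at least 1.2-fold lower number from compound 1 to compound 3 (0.08 log units; that floor lies within the scatter), so this comparison does not separate the two compounds.

On these data alone, the true distance from compound 1 stays open, and the step between compound 1 and compound 2 cannot be read, as the value of compound 1 is also a limit: the limit of >= 83200 nM in this assay, at which 1 of the 3 values shown sits. Also open is how 4-sulfamoylphenyl, or a phenyl carrying a carboxylic acid or an amine, would read in this assay.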